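A few compounds are considered here, and "the series" means these few. Any claim that something is new, unique, unknown or untested is made for them only; others in the source may bear on it.

Working notes on the series. Compound 1 `COc1cc2c(cc1CC=C(C)C)/C(=N/NC(N)=O)C[C@@H](c1ccc(O)cc1)O2` carries a semicarbazone on the shared core; in a functional assay on PC-3 cells (Homo sapiens) for inhibition, read by sulforhodamine B assay, with a stated time of 48 h, tested at 50 uM (a higher number here means more inhibition of growth at the concentration tested, a lower number less inhibition of growth), compound 1 gives 67%. Compound 2 `COc1ccc([C@@H]2C/C(=N/OCc3cn(-c4ccc(Cl)cc4C)nn3)c3cc(CC=C(C)C)c(OC)cc3O2)cc1` carries an oxime ether bearing a triazole with a 4-chloro-2-methylphenyl on an aromatic nitrogen; in this assay compound 2 gives 49%. Compound 3 `COc1ccc([C@@H]2C/C(=N/OCc3cn(-c4ccccc4CO)nn3)c3cc(CC=C(C)C)c(OC)cc3O2)cc1` has 2-(hydroxymethyl)phenyl in that place; in this assay compound 3 gives 100%, the highest of the three numbers, with compound 1 nearest and compound 2 furthest. Among the measured compounds shown here, the one measured step, a number 51 percentage points higher from compound 2 to compound 3 (beyond the scatter), shows that this aryl group sets the growth inhibition strongly.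

Compound 4 `COc1ccc([C@@H]2C/C(=N/OCc3cn(-c4cccc(CO)c4)nn3)c3cc(CC=C(C)C)c(OC)cc3O2)cc1` is the next member. Its difference from compound 3 is 3-(hydroxymethyl)phenyl in place of 2-(hydroxymethyl)phenyl on an aromatic nitrogen. For the measured compounds named here, no measured step moves a hydroxymethyl around the phenyl ring; the step from compound 2 to compound 3 exchanged the whole aryl group, so it bears on compound 4 only in showing that the aryl substituent matters, not in which direction a shift of the hydroxymethyl would act. Since the hydroxymethyl is kept, compound 4 is expected to stay near compound 3, with a modest downward step of a number 15 percentage points lower from compound 3 to compound 4 (beyond the scatter) allowed for the change of pattern. In this assay compound 4 is expected to give 85%, within 55% to 100%.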

Compound 4, percent growth inhibition at one concentration: 34%
Compound 4: middle estimate off by 51 percentage points, on the high side; the measured number lies below the stated range.
By their numbers in this assay, from the lowest: compound 4; then compound 2; then compound 1; then compound 3.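

The place of the hydroxymethyl on the phenyl ring, and not only its presence, sets the growth inhibition in this assay: the shift gives a number 66 percentage points lower from compound 3 to compound 4 (beyond the scatter) even though 2-(hydroxymethyl)phenyl and 3-(hydroxymethyl)phenyl have the same atoms and the same counts of hydrogen-bond donors and acceptors. Keeping a hydroxymethyl therefore does not by itself preserve the high number, since a number 15 percentage points lower from compound 2 to compound 4 (beyond the scatter) places the 3-(hydroxymethyl)phenyl group under the 4-chloro-2-methylphenyl group, which carries no hydroxymethyl at all. Nothing in hand gives a reason for the difference between the two placements.

Open, on these data alone, is whether the hydroxyl of the hydroxymethyl in compound 3 is itself needed, a question that an aminomethyl, a methoxymethyl, a carboxylic acid or a longer chain such as hydroxyethyl in that place would address. Also open, as far as these compounds go, is whether the strong dependence on this aryl group holds with other substituents on the phenyl ring, as two hydroxymethyl placements and one chloro-methyl pattern are too few to define a trend.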